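From Chloro to Fluoro on a Glutamate Receptor Antagonist

The source may report more compounds than this note shows. Statements on the series, on what has been measured and on what is new or still open speak of the compounds shown alone.

Compound 1 `Cc1cnnc(C#Cc2ccccc2)n1`: 140 nM
Compound 2 `Cc1cnnc(C#Cc2cccc(Cl)c2)n1`: 4.2 nM

Of the compounds shown here, two have so far been measured in a functional assay on CHO-K1 cells for antagonist activity at metabotropic glutamate receptor 5 (Homo sapiens), read by calcium flux; on this read-out higher numbers stand for weaker inhibition and lower numbers for stronger inhibition. Compound 1, the parent with an unsubstituted six-membered aromatic ring, gives 140 nM in this assay. Compound 2, which carries a chloro group on that ring, gives 4.2 nM. Within the data shown here, the only measured step is a 33-fold lower number from compound 1 to compound 2 (1.52 log units; beyond the scatter), so compound 2 stands at the lowest number of the two, with compound 1 at a clearly higher one.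

Compound 3 `Cc1cnnc(C#Cc2cccc(F)c2)n1` has not yet been measured. It differs from compound 2 by fluoro in place of chloro on an aromatic carbon, at the same place on the ring. Among the measured compounds shown here, the one step that bears on this change is the large drop seen from compound 1 to compound 2, where a chloro group entered in place of hydrogen. For the measured compounds named here, a fluoro group is a halogen like chloro, yet no measured compound shows what fluoro alone does here. The expectation is that compound 3 lands between compound 1 and compound 2, with an estimated step of a 4.8-fold higher number from compound 2 to compound 3 (0.68 log units; beyond the scatter). Compound 3 is therefore estimated at 20 nM, within a range of 5 nM to 80 nM.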

Compound 3, half-maximal inhibitory concentration: 96 nM
The estimate for compound 3 lay 4.8-fold (0.68 log units) below the measured number, outside the stated range (above it).
By their numbers in this assay, from the lowest: compound 2; then compounds 3 and 1 (each within the scatter of the next).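

In this assay, swapping one halogen for the other at this ring position is far from a small edit: a 23-fold higher number from compound 2 to compound 3 (1.36 log units; beyond the scatter) is what separates two groups that each count as a single heavy atom with no hydrogen-bond donors or acceptors. The parent compound now gives a second reference point, since a 1.5-fold lower number from compound 1 to compound 3 (0.16 log units; within the scatter) shows that fluoro in place of hydrogen makes no readable difference at this carbon. The large step of a 33-fold lower number from compound 1 to compound 2 (1.52 log units; beyond the scatter) therefore belongs to chloro in particular and does not extend to both halogens shown here, with compound 3 as the compound that goes against any rule covering halogens in general. Nothing available here accounts for the gap between chloro and fluoro.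

Three compounds cannot show whether this carbon favours chloro alone or would also accept other groups, such as bromo, methyl, methoxy or a nitrile. Going by these compounds, it also remains open whether chloro would give a comparable step on another carbon of the same ring, or whether the step seen with compound 2 holds only at this one place.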